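Acetoxy-to-hydroxy step on a biaryl core

The compounds below may be only part of what the source reports. "The series", "measured", "known", "first", "only" and "open" are said of these compounds alone.

Compound 1 `CC(=O)Oc1ccc(C(=O)Nc2cc3ccc(OC4CCN(C)CC4)c(C)c3oc2=O)cc1` is the reference; in a functional assay on SK-BR-3 cells (Homo sapiens) for antiproliferative activity (a lower number here means a stronger inhibitor, a higher number a weaker inhibitor), compound 1 gives 1670 nM. Compound 2 `Cc1c(OC2CCN(C)CC2)ccc2cc(NC(=O)c3ccc(O)cc3)c(=O)oc12` differs from compound 1 by hydrogen in place of acetyl on an oxygen on an aromatic ring and in this assay compound 2 gives 840 nM, so that a 2.0-fold lower number from compound 1 to compound 2 (0.30 log units; within the scatter). Compound 3 `COc1cccc(-c2cc(C(=O)Nc3cc4ccc(OC5CCN(C)CC5)c(C)c4oc3=O)ccc2OC(C)=O)c1` carries a different core, set apart from compound 1 by 3-methoxyphenyl in place of hydrogen on an aromatic carbon; in this assay compound 3 gives 920 nM, and a 1.8-fold lower number from compound 1 to compound 3 (0.26 log units; within the scatter). The values of compound 2 and compound 3 lie close to each other.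

Compound 4 `COc1cccc(-c2cc(C(=O)Nc3cc4ccc(OC5CCN(C)CC5)c(C)c4oc3=O)ccc2O)c1` is not yet measured. It differs from compound 3 by hydrogen in place of acetyl on an oxygen on an aromatic ring, the same change already seen between compound 1 and compound 2, and the surroundings of the place are the same in both cases. That single earlier occurrence moved the number only within the scatter, and nothing in the data shows whether the core of compound 3 alters the outcome. Among the measured compounds shown here, the step expected here is a 1.8-fold lower number from compound 3 to compound 4 (0.25 log units; within the scatter), set beside the earlier one because a 2.0-fold lower number from compound 1 to compound 2 (0.30 log units; within the scatter) is the only guide available. Compound 4 is therefore expected to give about 520 nM in this assay, with a plausible range from 230 nM to 1200 nM.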

Compound 4, half-maximal inhibitory concentration: 860 nM
Estimate against measurement, compound 4: 1.7-fold (0.22 log units) below; the measured number falls inside the stated range.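

In this assay, the acetoxy-to-hydroxy change on the core of compound 3 gives a 1.1-fold lower number from compound 3 to compound 4 (0.03 log units; within the scatter), and the gap to the same change on the core of compound 1 stays inside the noise: the same change on two cores in this assay, a 2.0-fold lower number (0.30 log units; within the scatter) from compound 1 to compound 2 and a 1.1-fold lower number (0.03 log units; within the scatter) from compound 3 to compound 4, 1.9-fold (0.27 log units) apart, within the scatter of two such steps

Adding 3-methoxyphenyl to the hydroxy compound gives a 1.0-fold higher number from compound 2 to compound 4 (0.01 log units; within the scatter), which likewise agrees with the same addition on the acetoxy compound: the same change on two cores in this assay, a 1.8-fold lower number (0.26 log units; within the scatter) from compound 1 to compound 3 and a 1.0-fold higher number (0.01 log units; within the scatter) from compound 2 to compound 4, 1.9-fold (0.27 log units) apart, within the scatter of two such steps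

The two cores therefore show no readable difference in how either change carries over, but every step here lies within the scatter, so this is agreement between small steps and does not show that either change moves the number or that a real effect transfers, and a single pair per change says nothing about other cores.

The compounds shown leave open whether a longer acyl chain in place of acetyl would give a step large enough to read. Also open, going by these compounds, is whether an amine or a carboxylic acid in place of the hydroxy would separate the two cores.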